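Swapping a fluorophenol for a trimethylphenyl in an antiproliferative series

The compounds below may be only part of what the source reports. "The series", "measured", "known", "first", "only" and "open" are said of these compounds alone.

Compound 2 `Cn1c(=O)c(=O)n(C2CCCC2)c2nc(N/N=C/c3ccc(O)c(F)c3)ncc21` is the weaker of the two measured compounds in a functional assay on PC-3 cells (Homo sapiens) for antiproliferative activity, read by MTT assay (a lower number here means a stronger inhibitor, a higher number a weaker inhibitor), giving 85200 nM. Compound 3 `Cn1c(=O)c(=O)n(C2CCCC2)c2nc(N/N=C/c3cc(C(F)(F)F)c(O)c(C(F)(F)F)c3)ncc21` gives 17700 nM in this assay. Compound 1 `Cn1c(=O)c(=O)n(C2CCCC2)c2nc(N/N=C/c3ccc(O)cc3)ncc21` reports only a limit in this assay, > 100000 nM. Among the measured compounds shown here, the one single-place step recorded, an at least 1.1-fold lower number from compound 1 to compound 2 (0.06 log units; that floor lies within the scatter), lies within the scatter. Compound 4 `Cc1cc(C)c(/C=N/Nc2ncc3c(n2)n(C2CCCC2)c(=O)c(=O)n3C)c(C)c1` carries the change (2,4,6-trimethylphenyl in place of 3-fluoro-4-hydroxyphenyl on a carbon with a double bond to nitrogen). For the measured compounds named here, no measured step shares this change, so the expectation rests loosely on the lower number of compound 3 and the limit of compound 1. Compound 4 is expected to give about 45000 nM in this assay, between 12000 nM and 150000 nM, an estimated step of a 1.9-fold lower number from compound 2 to compound 4 (0.28 log units; within the scatter).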

Compound 4, half-maximal inhibitory concentration: 13900 nM
Compound 4: middle estimate off by 3.2-fold (0.51 log units), on the high side; measured number inside the range.
By their numbers in this assay, from the lowest: compounds 4 and 3 (each within the scatter of the next); then compound 2. At a limit, above all of these: compound 1.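

Replacing 3-fluoro-4-hydroxyphenyl with 2,4,6-trimethylphenyl gives a 6.1-fold lower number from compound 2 to compound 4 (0.79 log units; beyond the scatter) in this assay, so on this carbon with a double bond to nitrogen, a ring with no hydroxy group still gives a lower number. The same replacement of 4-hydroxyphenyl gives an at least 7.1-fold lower number from compound 1 to compound 4 (0.85 log units; beyond the scatter). Compound 1 stands at a limit, so that step is only a floor: the limit of > 100000 nM in this assay, at which 1 of the 4 values shown sits.

The methyl groups enter together, so the compounds shown do not separate what each one contributes. Going by these compounds, whether an amine or a methoxy group on this ring would give a similar number also stays open.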